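A few compounds are considered here, and "the series" means these few. Any claim that something is new, unique, unknown or untested is made for them only; others in the source may bear on it.

Measured so far:
compound 1, `Nc1ccccc1NC(=O)c1ccc(CSc2ccc(Br)cc2)cc1`, 38.2%
compound 2, `Nc1ccccc1NC(=O)c1ccc(CSc2ccc(C(F)(F)F)cn2)cc1`, 16.5%

Both were tested in a functional assay on HeLa cells (Homo sapiens) for inhibition, read by CCK-8 assay, with a stated time of 72 h, tested at 8 uM; a higher number here means more inhibition of growth at the concentration tested, a lower number less inhibition of growth. Compound 1 has the higher of the two numbers; compound 2 sits lower by a gap beyond the scatter. Compound 3, `Cc1cc(C)cc(SCc2ccc(C(=O)Nc3ccccc3N)cc2)c1`, is not yet measured. It differs from compound 1 in one place: 3,5-dimethylphenyl in place of 4-bromophenyl on a sulfur. For the measured compounds named here, with no measured step of this kind to lean on, the expected change in this assay from compound 1 to compound 3 is small, a number 5.2 percentage points lower from compound 1 to compound 3 (within the scatter), likely within the scatter. Compound 3 is therefore estimated at 33%, with a range from 15% to 50%.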

Compound 3, percent growth inhibition at one concentration: 78.9%
Beside the measured number, compound 3's estimate is 45.9 percentage points below it; the whole stated range lies below it.
By their numbers in this assay, from the lowest: compound 2; then compound 1; then compound 3.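

Putting 3,5-dimethylphenyl in place of 4-bromophenyl on a sulfur gives a number 40.7 percentage points higher from compound 1 to compound 3 (beyond the scatter) in this assay and shows that the group on this sulfur can strongly change growth inhibition. Both groups have one six-membered aromatic ring of carbon only and no hydrogen-bond donors or acceptors, so these counts do not separate them. Nothing available explains this rise. The compounds shown leave open whether a single methyl group would give the same gain, and how a methoxy group or an amine on this ring would fare.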